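What a longer chain might do to compound 1

The compounds below may be only part of what the source reports. "The series", "measured", "known", "first", "only" and "open" are said of these compounds alone.

In a functional assay on MDA-MB-435 cells (Homo sapiens) for cytotoxicity (a higher number here means a weaker inhibitor of growth, a lower number a stronger inhibitor of growth), compound 1 `CCCCCCNC(=O)c1cc(NCc2cc(O)ccc2O)ccc1O` gives 15000 nM. Going by the values given here, its only measured neighbour, compound 2 `O=C(NCc1ccccc1)c1cc(NCc2cc(O)ccc2O)ccc1O`, gives 30000 nM, so the two stand level within the scatter.

Compound 3 `CCCCCCCCCCCCNC(=O)c1cc(NCc2cc(O)ccc2O)ccc1O` departs from compound 1 by a single change, (hexyl in place of hydrogen on a saturated chain carbon, six bonds along the chain from an amide-type nitrogen). The chain on the amide-type nitrogen therefore grows longer, while the shared core stays as it is.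

Just one measured step bears on this: a 2.0-fold higher number from compound 1 to compound 2 (0.30 log units; within the scatter). That step swaps the end of the chain for phenyl rather than extending it, and it stays within the scatter. Among the compounds with values here, the data hold no example of chain lengthening, so they suggest no direction, and no step beyond the scatter is expected in this assay. The expected step is no change at the digits printed from compound 1 to compound 3 (within the scatter), though with wide uncertainty. For compound 3 the estimate is 15000 nM, with a range of 3000 nM to 60000 nM.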

Compound 3, concentration for 50% growth inhibition: 3200 nM
Beside the measured number, compound 3's estimate is 4.7-fold (0.67 log units) above it; the measured number falls inside the stated range.
By their numbers in this assay, from the lowest: compound 3; then compounds 1 and 2 (each within the scatter of the next).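

Lengthening the chain on the amide-type nitrogen does register in this assay: adding hexyl in place of hydrogen gives a 4.7-fold lower number from compound 1 to compound 3 (0.67 log units; beyond the scatter) and so lowers the number needed for growth inhibition. Going by these compounds alone, the earlier swap at the end of the chain gave only a 2.0-fold higher number from compound 1 to compound 2 (0.30 log units; within the scatter) and stayed within the scatter, so this is the first sign that the position responds to a change. Still, the step is modest, and a single step is one comparison rather than a trend with chain length.

On these data alone, whether a still longer chain would lower the number further, or whether an amine or a carboxylic acid at the chain end would keep the gain, remains open. Nothing in the data shown explains why the longer chain gives the lower number.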